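The source may hold more compounds than are shown below. What is called first, only, known or untested is meant among the compounds shown, and "the series" means these compounds.

Measured in a functional assay on HCT-116 cells (Homo sapiens) for inhibition, read by ELISA, with a stated time of 24 h; a higher number here means a weaker inhibitor of growth, a lower number a stronger inhibitor of growth:
Compound 1 `CN1CCN(C(=O)ONC(=O)/C=C/c2ccccc2OC(=O)c2ccccc2)CC1`: 40400 nM
Compound 2 `CC(=O)ONC(=O)/C=C/c1ccccc1OC(=O)c1ccccc1`: 21300 nM
Compound 3 `CN1CCN(C(=O)/C=C/c2ccccc2OC(=O)c2ccccc2)CC1`: > 100000 nM, a limit of the assay and not a number

Compound 2 stands at the low end of this small set, the stronger end, but it has no clear lead over its nearest neighbour. The two numbers are level, with a 1.9-fold lower number from compound 1 to compound 2 (0.28 log units; within the scatter).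

Compound 4 `O=C(/C=C/c1ccccc1OC(=O)c1ccccc1)NOC(=O)c1ccccc1` keeps the shared core and has phenyl in place of methyl on a carbonyl carbon. Within the data shown here, the closest precedent is a swap on that same carbonyl carbon, methyl in place of 4-methylpiperazin-1-yl, which gave a 1.9-fold lower number from compound 1 to compound 2 (0.28 log units; within the scatter). The larger change, 4-methylpiperazin-1-yl in place of acetoxyamino, gave an at least 4.6-fold higher number from compound 2 to compound 3 (0.67 log units; beyond the scatter), but compound 4 makes no such change. One precedent is thin evidence, so the range stays wide, and no step beyond the scatter is expected in this assay. The expected change is a 1.2-fold lower number from compound 2 to compound 4 (0.07 log units; within the scatter). Compound 4 is estimated at 18000 nM, with an expected range of 6000 nM to 50000 nM.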

Compound 4, concentration for 50% growth inhibition: 13600 nM
Beside the measured number, compound 4's estimate is 1.3-fold (0.12 log units) above it; measured number inside the range.
By their numbers in this assay, from the lowest: compounds 4, 2 and 1 (each within the scatter of the next, the first and the last beyond it). At a limit, above all of these: compound 3.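

In this assay phenyl in place of methyl on a carbonyl carbon gives a 1.6-fold lower number from compound 2 to compound 4 (0.19 log units; within the scatter) and so leaves the two compounds level, even though the group entering has six heavy atoms and a six-membered aromatic ring where the group leaving has one carbon. The new compound does add something that compounds 1 and 2 could not show: phenyl in place of 4-methylpiperazin-1-yl at this same place gives a 3.0-fold lower number from compound 1 to compound 4 (0.47 log units; beyond the scatter) and so opens a modest gap, where methyl in place of 4-methylpiperazin-1-yl had stayed within the scatter. Nothing measured here explains why these groups compare as they do.

What the compounds shown leave open is how a longer chain such as hexyl would compare at this carbonyl carbon. The same question stands for a phenyl ring carrying an amine or a carboxylic acid.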